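Replacing the selenol by methylsulfanyl on the shared core

A few compounds are considered here, and "the series" means these few. Any claim that something is new, unique, unknown or untested is made for them only; others in the source may bear on it.

Measured compounds:
`C[Se]c1nc(N)c2ccccc2n1` compound 1, 18000 nM
`CSc1ccc(CNc2nc([SeH])nc3ccccc23)cc1` compound 2, 45500 nM
`[SeH]c1nc(NCc2ccccc2)c2ccccc2n1` compound 3, 31200 nM

In a functional assay on HTB-54 cells (Homo sapiens) for cytotoxicity, read by MTT assay, with a stated time of 72 h (on this read-out higher numbers stand for weaker inhibition of growth and lower numbers for stronger inhibition of growth), compound 2 gives 45500 nM, the highest of the three numbers; compound 3 sits within the scatter of it, and compound 1 lies beyond the scatter on the lower side. Compound 4, `CSc1ccc(CNc2nc(SC)nc3ccccc23)cc1`, differs from compound 2 by a group of 2 heavy atoms (1 carbon, 1 sulfur; no ring) in place of one selenium atom, on an aromatic carbon. For the measured compounds named here, the only measured step, a 1.5-fold lower number from compound 2 to compound 3 (0.16 log units; within the scatter), concerns the other end of the molecule and does not touch this change, so nothing measured bears on it directly. With no guide, the expectation is for no step beyond the scatter. Compound 4 is therefore expected to give 40000 nM, with a range from 15000 nM to 120000 nM, which would mean a 1.1-fold lower number from compound 2 to compound 4 (0.06 log units; within the scatter).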

Compound 4, concentration for 50% growth inhibition: 7220 nM
Beside the measured number, compound 4's estimate is 5.5-fold (0.74 log units) above it; the whole stated range lies above it.
By their numbers in this assay, from the lowest: compound 4; then compounds 1, 3 and 2 (each within the scatter of the next, the first and the last beyond it).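

In this assay, methylsulfanyl in place of the selenium on the aromatic carbon between two ring nitrogen atoms gives a 6.3-fold lower number from compound 2 to compound 4 (0.80 log units; beyond the scatter) and so shows that this position responds beyond the scatter, whereas a 1.5-fold lower number from compound 2 to compound 3 (0.16 log units; within the scatter) at the other end of the molecule stays within it. Nothing shown gives a reason for this step. The compounds shown leave open how an amine or the longer ethylsulfanyl chain would fare at this carbon, and whether the methyl or the sulfur carries the step.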